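A few compounds are considered here, and "the series" means these few. Any claim that something is new, unique, unknown or untested is made for them only; others in the source may bear on it.

Measured compounds in a functional assay on HFF cells (Homo sapiens) for inhibition; a higher number here means a weaker inhibitor, a lower number a stronger inhibitor:
Compound 1, `Cc1nsc2[nH]c(SCc3ccccc3)nc12`, gives 10000 nM.
Compound 2, `c1ccc(CSc2nc3cnsc3[nH]2)cc1`, gives 14000 nM.
Compound 3, `CSc1nc2c(C)nsc2n1[C@@H]1O[C@H](CO)[C@@H](O)[C@@H]1O`, gives only a limit of the assay, > 100000 nM.

Compound 1 and compound 2 share a core and differ in one place: hydrogen in place of methyl on an aromatic carbon. That change made a 1.4-fold higher number from compound 1 to compound 2 (0.15 log units; within the scatter) in this assay, so the two values are indistinguishable here.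

Compound 3 carries a different core, and the difference between the two cores is not broken down here. For compound 3 no number is known, only the limit (the limit of > 100000 nM in this assay, at which 1 of the 3 values shown sits).

Compound 4, `CSc1nc2cnsc2n1[C@@H]1O[C@H](CO)[C@@H](O)[C@@H]1O`, has not yet been measured in this assay. It differs from compound 3 by hydrogen in place of methyl on an aromatic carbon. For the measured compounds named here, this is the same change as the one from compound 1 to compound 2, at a place described in identical words.

For compound 4 the expectation rests on two things: the step made by the same change between measured compounds, a 1.4-fold higher number from compound 1 to compound 2 (0.15 log units; within the scatter), which lies within the scatter, and the fact that compound 3 itself reached only a limit, > 100000 nM. A step that the limit leaves unreadable from compound 3 to compound 4 is therefore expected from compound 3 to compound 4, which would leave compound 4 at or beyond the same limit. Compound 4 is estimated at 150000 nM in this assay, with the likely range 50000 nM to 500000 nM, and with a high chance that the assay again reports only a limit and no number.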

Compound 4, half-maximal inhibitory concentration: > 100000 nM
Compound 4: no number, only a limit; the forecaster's own chance of this, stated with the estimate: 80%; the middle value does not contradict the limit.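

In this assay compound 4 gives only a limit of the assay, > 100000 nM. No step can be read between compound 3 and compound 4, since both reach only a limit: the limit of > 100000 nM in this assay, at which 2 of the 4 values shown sit.

The compounds shown leave open whether hydrogen in place of methyl on an aromatic carbon changes the value at all on the core of compound 3, where neither compound gives a number.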